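The source may hold more compounds than are shown below. What is called first, only, known or untested is meant among the compounds shown, and "the series" means these compounds.

The compounds share one core and are read in a functional assay on HeLa cells (Homo sapiens) for antiproliferative activity, with a stated time of 24 h; a higher number here means a weaker inhibitor, a lower number a stronger inhibitor. Compound 1 `NC(=O)c1c(NC(=O)c2ccccc2Cl)sc2c1CCN(Cc1ccccc1F)C2` gives > 50000 nM, which is a limit and not a number. Compound 3 `NC(=O)c1c(NC(=O)c2ccc(C(F)(F)F)cc2)sc2c1CCN(Cc1ccccc1F)C2` gives > 50000 nM, again only a limit. Compound 2 `NC(=O)c1c(NC(=O)c2ccccc2Cl)sc2c1CCN(Cc1ccc(Cl)cc1Cl)C2` gives 21100 nM. Compound 3 therefore stands at the limit of > 50000 nM in this assay, at which 2 of the 3 values shown sit.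

Compound 4 `NC(=O)c1c(NC(=O)c2ccc(C(F)(F)F)cc2)sc2c1CCN(Cc1c(Cl)cccc1Cl)C2` differs from compound 3 in one place: 2,6-dichlorophenyl in place of 2-fluorophenyl on a saturated chain carbon bound to an amine nitrogen in a ring. The closest measured change lies at that same place, where 2,4-dichlorophenyl replaces 2-fluorophenyl, and it amounts to an at least 2.3-fold lower number from compound 1 to compound 2 (0.37 log units; beyond the scatter). The other measured change, on a carbonyl carbon, is a step that the two limits leave unreadable from compound 1 to compound 3, so it gives no size to carry over. Given compound 2 at 21100 nM, a modest lowering of the number is expected. It would be no surprise if compound 4 also gave only a limit. For the step itself, the expectation is an at least 1.7-fold lower number from compound 3 to compound 4 (0.25 log units; that floor lies within the scatter). The estimated value for compound 4 is 28000 nM, with an expected range of 11000 nM to 60000 nM.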

Compound 4, half-maximal inhibitory concentration: > 50000 nM
Compound 4: no number, only a limit; the forecaster's own chance of this, stated with the estimate: 40%; at least 1.7-fold (0.25 log units) between middle value and limit.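

Compound 3 and compound 4 both give only a limit in this assay, so the step between them cannot be read: the limit of > 50000 nM in this assay, at which 3 of the 4 values shown sit.

The compounds shown leave open whether 2,6-dichlorobenzyl in place of 2-fluorobenzyl changes the number in this assay at all.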